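The source may report more compounds than this note shows. Statements on the series, on what has been measured and on what is new or still open speak of the compounds shown alone.

Compound 1 `CC(C)(C)OC(=O)Nc1ncc(C(Oc2ccc3cc(Br)ccc3c2)c2ccc(Cl)cc2)s1` and compound 2 `CCCCCC(=O)Nc1ncc(C(Oc2ccc3cc(Br)ccc3c2)c2ccc(Cl)cc2)s1` share one core and differ only at a carbonyl carbon. In an ADME assay on HepG2 2.2.15 cells (Homo sapiens) for cytotoxicity (a higher number here means that more compound is tolerated, a lower number that less compound is tolerated), compound 1 gives the limit > 50000 nM. In this assay compound 2 gives the limit > 50000 nM. The step that the two limits leave unreadable from compound 1 to compound 2 is thus not readable in size, and the limit of > 50000 nM in this assay, at which 2 of the 2 values shown sit, is all the measured pair offers. Compound 3 `O=C(Nc1ncc(C(Oc2ccc3cc(Br)ccc3c2)c2ccc(Cl)cc2)s1)C1CCCO1` differs from compound 2 by oxolan-2-yl in place of pentyl on a carbonyl carbon. No readable step bears on this change, so the expected step that the limit leaves unreadable from compound 2 to compound 3 lies within the scatter. Compound 3 is therefore estimated at 60000 nM, with a range from 25000 nM to 150000 nM, most likely again reported as a limit.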

Compound 3, half-maximal cytotoxic concentration: "not toxic" (no number reported)
The entry for compound 3 holds no number; there is nothing to compare the estimate with.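

No new step can be read, since compound 3 is recorded in this assay as not toxic without a number, and compound 2 gives only a limit. What the compounds shown leave open is how far oxolan-2-yl in place of pentyl shifts tolerated concentration.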